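Aryl swaps on the ester chain: notes on compound 3

This account rests on a few compounds, and the source may have more. Where it says the series, first, only, none or still open, it means among the compounds named here.

The shared core carries an ester whose chain ends in an aromatic group. Compound 1 `COc1cc(/C=C/C(=O)OCCc2ccccc2F)cc(OC)c1O` and compound 2 `COc1cccc(CCOC(=O)/C=C/c2cc(OC)c(O)c(OC)c2)c1` differ only there. In an assay on PMNL cells for inhibition of Polyunsaturated fatty acid 5-lipoxygenase (Homo sapiens), read by HPLC, with stated times of 5 min and 15 min (a lower number here means a stronger inhibitor, a higher number a weaker inhibitor), compound 1 gives 240 nM, and in this assay compound 2 gives 210 nM. The step of a 1.1-fold lower number from compound 1 to compound 2 (0.06 log units; within the scatter) shows that exchanging one substituted aryl for another at this chain position leaves the number essentially unchanged. Among the measured compounds shown here, compound 2 holds the lowest of the two numbers so far, with compound 1 nearest at a gap within the scatter, so no order between them can be claimed.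

Compound 3 `COc1cc(/C=C/C(=O)OCCCc2ccccc2)cc(OC)c1O` is not yet measured. Its difference from compound 2 is benzyl in place of 3-methoxyphenyl on a saturated chain carbon, two bonds along the chain from an oxygen next to a carbonyl group. For the measured compounds named here, the only measured step that bears on it is the one from compound 1 to compound 2, an aryl exchange at the same place, which stayed within the scatter. On that basis the expected step of a 1.1-fold higher number from compound 2 to compound 3 (0.04 log units; within the scatter) is none beyond the scatter. For compound 3 in this assay the estimate is 230 nM, within a range from 110 nM to 480 nM.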

Compound 3, half-maximal inhibitory concentration: 340 nM
Compound 3: middle estimate off by 1.5-fold (0.17 log units), on the low side; the range from low to high includes it.
By their numbers in this assay, from the lowest: compounds 2, 1 and 3 (each within the scatter of the next).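

In this assay, benzyl at this place, on a saturated chain carbon two bonds along the chain from an oxygen next to a carbonyl group, gives a 1.6-fold higher number from compound 2 to compound 3 (0.21 log units; within the scatter) and a 1.4-fold higher number from compound 1 to compound 3 (0.15 log units; within the scatter), so the three end groups cannot be put in any order. The earlier step covered only an exchange of one substituted aryl for another, whereas these two steps show that benzyl, which carries neither the oxygen of 3-methoxyphenyl nor the fluorine of 2-fluorophenyl, also produces no step beyond the scatter at this place. No measurement at hand offers an explanation for the size of these steps.

The compounds shown all end in a six-membered aromatic ring of carbon only, so it remains open how an amine or a carboxylic acid at the end of the chain would read in this assay. Going by these compounds, it also remains open whether a longer chain, or a ring containing nitrogen such as pyridyl, would give any step beyond the scatter at this place.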